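Swapping an Open Diamine Chain for a Piperazine Ring

The source may report more compounds than this note shows. Statements on the series, on what has been measured and on what is new or still open speak of the compounds shown alone.

Of the compounds shown here, two have so far been measured in a functional assay on U-87MG ATCC cells (Homo sapiens) for cytotoxicity, read by MTT assay, with a stated time of 72 h; a higher number here means a weaker inhibitor, a lower number a stronger inhibitor. Compound 1 `COc1ncc(-c2ccc3nccc(N4CCCC4)c3c2)cc1NS(=O)(=O)c1ccc(F)cc1F` gives 6690 nM. Compound 2 `CNCCN(C)Cc1ccc(-c2ccnc3ccc(-c4cnc(OC)c(NS(=O)(=O)c5ccc(F)cc5F)c4)cc23)cc1`, which carries a longer side arm ending in a methyl(2-(methylamino)ethyl)amino group, gives 254 nM; this is the lower of the two numbers, and its gap to compound 1 lies well beyond the usual scatter of repeated measurements.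

Compound 3 `COc1ncc(-c2ccc3nccc(-c4ccc(CN5CCN(C(C)C)CC5)cc4)c3c2)cc1NS(=O)(=O)c1ccc(F)cc1F` differs from compound 2 in a single place: 4-isopropylpiperazin-1-yl in place of methyl(2-(methylamino)ethyl)amino on a saturated chain carbon bound to an aromatic carbon. The open chain is thus closed into a six-membered ring carrying an isopropyl group, while the rest of the molecule is unchanged. Among the compounds with values here, no measured pair shows this kind of change, so its effect can only be estimated. Compound 3 is expected to land near 300 nM, most likely between 100 nM and 900 nM. The step expected in this assay, a 1.2-fold higher number from compound 2 to compound 3 (0.07 log units; within the scatter), is one that stays within the scatter, in no clear direction.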

Compound 3, half-maximal inhibitory concentration: 468 nM
Compound 3: the middle estimate sits 1.6-fold (0.19 log units) below what was measured, within the range that was stated.
By their numbers in this assay, from the lowest: compounds 2 and 3 (each within the scatter of the next); then compound 1.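

In this assay, closing the open methyl(2-(methylamino)ethyl)amino chain into the 4-isopropylpiperazin-1-yl ring is a 1.8-fold higher number from compound 2 to compound 3 (0.27 log units; within the scatter) and so does not separate the two groups at this saturated chain carbon bound to an aromatic carbon. Within the data shown here, the single change removes the hydrogen-bond donor of the open chain and adds a six-membered ring, yet the two numbers remain within the scatter of each other. Nothing at hand explains why these two different groups read alike.

The compounds shown leave open whether an unsubstituted piperazine or a morpholine ring at this place would also stay within the scatter of compound 3. They also leave open how a carboxylic acid or a longer diamine chain there would read.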